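The source may report more compounds than this note shows. Statements on the series, on what has been measured and on what is new or still open speak of the compounds shown alone.

In a functional assay on SW-620 cells (Homo sapiens) for cytotoxicity (on this read-out lower numbers stand for stronger inhibition and higher numbers for weaker inhibition), compound 1 `COc1ccc2nc(NC(=O)CCCCC(=O)NO)sc2c1` gives 9.07 ug/mL and compound 2 `CS(=O)(=O)c1ccc2nc(NC(=O)CCCCCCC(=O)NO)sc2c1` gives 5.42 ug/mL. Compound 3 `CS(=O)(=O)c1ccc2nc(NC(=O)CCCCC(=O)NO)sc2c1` reaches only the limit of this assay, > 30 ug/mL. Compound 3 thus stands at the weak end of the three measured compounds, reached by two steps: an at least 3.3-fold higher number from compound 1 to compound 3 (0.51 log units; beyond the scatter) and an at least 5.5-fold higher number from compound 2 to compound 3 (0.74 log units; beyond the scatter). Compound 4 `O=C(CCCCC(=O)Nc1nc2ccc([N+](=O)[O-])cc2s1)NO` differs from compound 3 in one place: nitro in place of methylsulfonyl on an aromatic carbon. Among the compounds with values here, only the step from compound 1 to compound 3 touches this aromatic carbon, and no measured step involves a nitro, so the direction of the new step is uncertain. Compound 4 is expected to give 18 ug/mL, within a range from 6 ug/mL to 30 ug/mL. This corresponds to an expected step of an at least 1.6-fold lower number from compound 3 to compound 4 (0.22 log units; that floor lies within the scatter), with a real chance that compound 4 also returns only a limit.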

Compound 4, half-maximal inhibitory concentration: > 30 ug/mL
Compound 4: no number, only a limit; the forecaster's own chance of this, stated with the estimate: 40%; middle value at least 1.6-fold (0.22 log units) from the limit.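

Replacing methoxy with nitro on this aromatic carbon gives an at least 3.3-fold higher number from compound 1 to compound 4 (0.51 log units; beyond the scatter). On this chain, nitro thus joins methylsulfonyl as a second group that leaves only a limit where methoxy gives a measured value. The change from methylsulfonyl to nitro itself cannot be read because both values are limits: the limit of > 30 ug/mL in this assay, at which 2 of the 4 values shown sit.

The compounds shown leave open whether nitro would give a measured value on the longer chain of compound 2, as methylsulfonyl does there. They also leave open how an amine on this aromatic carbon would read.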